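Aryl swap on the oxazole core and Huh7.5.1 cytotoxicity

The source may hold more compounds than are shown below. What is called first, only, known or untested is meant among the compounds shown, and "the series" means these compounds.

Measured compounds:
compound 1 `Cc1oc(-c2ccccc2Cl)nc1CN1CCC(C(=O)NCCCN2C[C@H](C)C[C@H](C)C2)CC1` — 16500 nM
compound 2 `Cc1ccccc1-c1nc(CN2CCC(C(=O)NCCCN3CCC(C(C)C)CC3)CC2)c(C)o1` — 4280 nM
compound 3 `Cc1ccccc1-c1nc(CN2CCC(C(=O)NCCCN3CCCC(CC(C)C)C3)CC2)c(C)o1` — 4640 nM

In an ADME assay on Huh7.5.1 cells (Homo sapiens) for cytotoxicity, read by ATP content, with a stated time of 48 h (on this read-out lower numbers stand for higher toxicity in this test and higher numbers for lower toxicity in this test), compound 1 gives the highest of the three numbers, standing beyond the scatter above compound 3 and compound 2. Within the data shown here, the one counted step, a 1.1-fold higher number from compound 2 to compound 3 (0.04 log units; within the scatter), concerns the ring at the far end of the chain, not the aryl group, and lies within the scatter.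

Compound 4 `COc1ccc(-c2nc(CN3CCC(C(=O)NCCCN4C[C@H](C)C[C@H](C)C4)CC3)c(C)o2)cc1OC` differs from compound 1 by 3,4-dimethoxyphenyl in place of 2-chlorophenyl on an aromatic carbon. Among the measured compounds shown here, no measured pair alters this aryl group, so nothing among the steps bears directly on the change; the series only shows that the number of compound 1 sits well above those of compound 2 and compound 3, which carry a different aryl group and different distal rings. With no guide for the aryl change, compound 4 is expected to stay near compound 1, the expected step of a 1.1-fold lower number from compound 1 to compound 4 (0.04 log units; within the scatter) being small. The estimate for compound 4 is 15000 nM, within 5000 nM to 45000 nM.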

Compound 4, half-maximal cytotoxic concentration: 57200 nM
Compound 4: the middle estimate sits 3.8-fold (0.58 log units) below what was measured; measured number outside the range, above it.
By their numbers in this assay, from the lowest: compounds 2 and 3 (each within the scatter of the next); then compound 1; then compound 4.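

The aryl group on this aromatic carbon of the shared core matters in this assay: with the rest of compound 1 unchanged, 3,4-dimethoxyphenyl in place of 2-chlorophenyl gives a 3.5-fold higher number from compound 1 to compound 4 (0.54 log units; beyond the scatter), which here means lower toxicity in this test. The only earlier step, a 1.1-fold higher number from compound 2 to compound 3 (0.04 log units; within the scatter), concerned the ring at the far end of the chain and stayed within the scatter, so this is the first change shown to move the number beyond it. No supporting measurement bears on why the number rises with this swap.

The compounds shown leave open whether a single methoxy group, as in 4-methoxyphenyl, or an unsubstituted phenyl would give a similar number. They also leave open whether the same aryl swap would carry over to the far-end rings of compound 2 and compound 3.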